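This account rests on a few compounds, and the source may have more. Where it says the series, first, only, none or still open, it means among the compounds named here.

Compound 1 `COc1ccccc1C(=O)NCCNc1cccc(NS(=O)(=O)c2cc(-c3cccc(C(=O)N(C)C)c3)ccc2OC)c1` and compound 2 `COc1ccccc1C(=O)NCCNc1cccc(NS(=O)(=O)c2cc(-c3cccc(C(=O)N4CCC4)c3)ccc2OC)c1` share one core and differ only in the group on the carbonyl carbon of the phenyl ring. In an assay on CHO-K1 cells for agonist activity at Orexin receptor type 2 (Homo sapiens), read by a luciferase reporter (a higher number here means that more compound is needed for the effect, a lower number that less compound is needed), compound 1 gives 50 nM, while compound 2 gives 235 nM. The step of a 4.7-fold higher number from compound 1 to compound 2 (0.67 log units; beyond the scatter) is a modest loss on exchanging dimethylamino for azetidin-1-yl on that carbonyl carbon. Within the data shown here, of the two numbers measured, compound 2 stands highest, with compound 1 as its only neighbour.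

Compound 3 `COc1ccccc1C(=O)NCCNc1cccc(NS(=O)(=O)c2cc(-c3cccc(F)c3)ccc2OC)c1` has not yet been measured. It differs from compound 2 by fluoro in place of (azetidin-1-yl)carbonyl on an aromatic carbon; cut one bond further out, the change reads 3-((azetidin-1-yl)carbonyl)phenyl to 3-fluorophenyl. Among the measured compounds shown here, only the step from compound 1 to compound 2 touches the same place, and it altered the amide rather than removing it, so no measured step shows what taking away the carbonyl and its four-membered ring does. Because altering the amide alone already produced a 4.7-fold higher number from compound 1 to compound 2 (0.67 log units; beyond the scatter), removing the whole group is expected to cost more. Compound 3 is therefore expected to give a higher number in this assay, about 1500 nM, within 300 nM to 8000 nM, an expected step of a 6.4-fold higher number from compound 2 to compound 3 (0.81 log units; beyond the scatter).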

Compound 3, half-maximal effective concentration: > 10000 nM
Compound 3: only a limit was reported; the forecaster's own chance of this, stated with the estimate: 20%; middle value at least 6.6-fold (0.82 log units) away from the limit.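

In this assay compound 3 gives only a limit, > 10000 nM, and not a number. On this aromatic carbon, fluoro in place of (azetidin-1-yl)carbonyl gives an at least 42-fold higher number from compound 2 to compound 3 (1.62 log units; beyond the scatter), and fluoro in place of dimethylcarbamoyl gives an at least 200-fold higher number from compound 1 to compound 3 (2.30 log units; beyond the scatter), both far larger than the change within the amide, a 4.7-fold higher number from compound 1 to compound 2 (0.67 log units; beyond the scatter). Among these compounds, the earlier pair showed only that the group on the carbonyl carbon can be altered at a modest cost, whereas these steps show that activity in the tested range is lost once fluoro stands in place of the whole amide, and their true size stays open because they rest on a limit: the limit of > 10000 nM in this assay, at which 1 of the 3 values shown sits.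

The compounds shown leave open whether the loss follows from the absence of the carbonyl, the absence of the amide nitrogen and its substituents, or the presence of fluoro itself. A primary carboxamide, a carboxylic acid, a methyl ester, a nitrile or plain hydrogen at this carbon could separate these readings, and a larger amine such as pyrrolidine or morpholine on the carbonyl would show how far the trend from compound 1 to compound 2 extends.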